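The source may report more compounds than this note shows. Statements on the series, on what has been measured and on what is new or still open speak of the compounds shown alone.

Measured compounds:
- compound 1, `O=C(Nc1nc2ccc(F)cc2s1)c1cn(-c2ccccc2)nc1-c1ccccc1`: 9800 nM
- compound 2, `O=C(Nc1nc2ccc(F)cc2s1)c1cn(-c2ccccc2)nc1-c1ccc(F)cc1`: 4160 nM
- compound 3, `O=C(Nc1nc2ccccc2s1)c1cn(-c2ccccc2)nc1-c1ccc(Cl)cc1`: 13700 nM

In a functional assay on HT-29 cells (Homo sapiens) for cytotoxicity, read by MTT assay, with a stated time of 72 h (a lower number here means a stronger inhibitor, a higher number a weaker inhibitor), compound 3 gives the highest of the three numbers. Compound 1 is nearest, its value within the scatter of that of compound 3; compound 2 is furthest, beyond the scatter. Compound 4, `O=C(Nc1nc2ccc(F)cc2s1)c1cn(-c2ccccc2)nc1-c1ccc(Cl)cc1`, is not yet measured. Compound 4 differs from compound 3 by fluoro in place of hydrogen on an aromatic carbon, on an aromatic carbon of the fused two-ring part of the shared core.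

Going by the values given here, the only single-place step on record, a 2.4-fold lower number from compound 1 to compound 2 (0.37 log units; beyond the scatter), is a fluoro-for-hydrogen change on a different ring, the pendant six-membered ring rather than the fused system, so it bears on the present change only as a loose analogue. Compounds 1 and 3, which differ in two places, including the same fluoro, show values within the scatter of each other, which gives no clear direction. On that basis a change of at most modest size is expected, toward a lower number if any, and possibly none beyond the scatter. Compound 4 is expected at 7500 nM, range 3000 nM to 18000 nM, an expected step of a 1.8-fold lower number from compound 3 to compound 4 (0.26 log units; within the scatter).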

Compound 4, half-maximal inhibitory concentration: 4970 nM
The estimate for compound 4 lay 1.5-fold (0.18 log units) above the measured number; low and high end bracket the measured number.
By their numbers in this assay, from the lowest: compounds 2, 4, 1 and 3 (each within the scatter of the next, the first and the last beyond it).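

In this assay, fluoro in place of hydrogen on an aromatic carbon of the fused two-ring part now has a single-place step of its own, a 2.8-fold lower number from compound 3 to compound 4 (0.44 log units; beyond the scatter), whereas the earlier fluoro step lay on another ring. The same exchange thus gives a step of similar size at two places: the same change on two cores in this assay, a 2.4-fold lower number (0.37 log units; beyond the scatter) from compound 1 to compound 2 and a 2.8-fold lower number (0.44 log units; beyond the scatter) from compound 3 to compound 4, 1.2-fold (0.07 log units) apart, within the scatter of two such steps. With 6-fluoro-1,3-benzothiazol-2-yl held constant, chloro in place of hydrogen gives a 2.0-fold lower number from compound 1 to compound 4 (0.29 log units; within the scatter) and chloro in place of fluoro gives a 1.2-fold higher number from compound 2 to compound 4 (0.08 log units; within the scatter), both within the scatter, so these steps do not separate the three groups on that ring.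

Going by these compounds, whether a methoxy group or an amine at the fused-ring position would shift the number further remains open. So does whether these small steps carry over to cell lines other than HT-29.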